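Removing a Bromine from a Benzyl Thioether Triazole

The source may report more compounds than this note shows. Statements on the series, on what has been measured and on what is new or still open speak of the compounds shown alone.

Measured so far, in a functional assay on HCT-116 cells (Homo sapiens) for inhibition, read by MTT assay, with a stated time of 48 h; a lower number here means a stronger inhibitor, a higher number a weaker inhibitor:
- compound 1 `Fc1ccccc1CSc1nnc(-c2ccncc2)n1-c1ccccc1` gives 12000 nM
- compound 2 `Brc1cccc(CSc2nnc(-c3ccncc3)n2-c2ccccc2)c1` gives 8170 nM

The two compounds share one core and differ only in the substituent on the benzyl ring. The step of a 1.5-fold lower number from compound 1 to compound 2 (0.17 log units; within the scatter) is small, so compound 2 stands within the scatter of compound 1 and neither can be called the stronger. Compound 3 `c1ccc(CSc2nnc(-c3ccncc3)n2-c2ccccc2)cc1` follows from compound 2 by hydrogen in place of bromo on an aromatic carbon. Among the compounds with values here, only the step from compound 1 to compound 2 bears on this, and it was within the scatter, so no shift beyond the scatter is expected in this assay. The estimate for compound 3 is 11000 nM, ranging from 5000 nM to 25000 nM, an expected step of a 1.3-fold higher number from compound 2 to compound 3 (0.13 log units; within the scatter).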

Compound 3, half-maximal inhibitory concentration: 16900 nM
For compound 3 the middle estimate is 1.5-fold (0.19 log units) below the measured one; the range from low to high includes it.
By their numbers in this assay, from the lowest: compounds 2, 1 and 3 (each within the scatter of the next, the first and the last beyond it).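

In this assay, within the data shown here, swapping bromo for hydrogen on the benzyl ring gives the only step so far that lies beyond the scatter, a 2.1-fold higher number from compound 2 to compound 3 (0.32 log units; beyond the scatter), so this place on the ring can register a modest change. Swapping fluoro for hydrogen gives a 1.4-fold higher number from compound 1 to compound 3 (0.15 log units; within the scatter), which stays within the scatter, so that change cannot be read as a shift. No evidence here explains the difference between these steps. Still open, on these data alone, is how groups such as an amine or a carboxylic acid would compare with bromo on this ring.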